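Chloro in place of isopropyl on the second aryl ring

The source may hold more compounds than are shown below. What is called first, only, known or untested is meant among the compounds shown, and "the series" means these compounds.

Of the compounds shown here, two sharing one core have so far been tested in a functional assay on MGC-803 cells (Homo sapiens) for inhibition, read by MTT assay, with a stated time of 72 h; a lower number here means a stronger inhibitor, a higher number a weaker inhibitor. Compound 1 `COc1ccc(Nc2nc(SCc3cn(CC(=O)NC(=O)Nc4ccccn4)nn3)nc(-c3ccc(C(C)C)cc3)c2C#N)cc1` carries a methoxy on its aniline ring; in this assay compound 1 returns only a limit, > 64000 nM. Compound 2 `CC(C)c1ccc(Nc2nc(SCc3cn(CC(=O)NC(=O)Nc4ccccn4)nn3)nc(-c3ccc(C(C)C)cc3)c2C#N)cc1` carries an isopropyl in place of that methoxy, and in this assay compound 2 gives 15800 nM. Among the compounds with values here, the step of an at least 4.0-fold lower number from compound 1 to compound 2 (0.60 log units; beyond the scatter) is the only measured comparison, and it leaves compound 2 as the one compound with an actual number, the other value sitting at the limit of > 64000 nM in this assay, at which 1 of the 2 values shown sits.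

Compound 3 `CC(C)c1ccc(Nc2nc(SCc3cn(CC(=O)NC(=O)Nc4ccccn4)nn3)nc(-c3ccc(Cl)cc3)c2C#N)cc1` differs from compound 2 in a single place: chloro in place of isopropyl on an aromatic carbon. Within the data shown here, no measured step concerns this ring. The step of an at least 4.0-fold lower number from compound 1 to compound 2 (0.60 log units; beyond the scatter) bears on the new change only as a sign that swapping one substituent on an aromatic carbon of this core can move the number beyond the scatter, without telling the direction. Compound 3 is therefore expected near the position of compound 2, with wide uncertainty, at 22000 nM between 6000 nM and 64000 nM, a step of a 1.4-fold higher number from compound 2 to compound 3 (0.14 log units; within the scatter) that is an estimate only.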

Compound 3, half-maximal inhibitory concentration: 16900 nM
For compound 3 the middle estimate is 1.3-fold (0.11 log units) above the measured one; the measured number falls inside the stated range.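

Within the data shown here, putting 4-chlorophenyl in place of 4-isopropylphenyl gives a 1.1-fold higher number from compound 2 to compound 3 (0.03 log units; within the scatter) in this assay, the first measured comparison on the second aryl ring. On this aromatic carbon, para to a large group, an isopropyl of 3 carbon heavy atoms and a chloro of 1 chlorine atom therefore cannot be told apart in this assay, whereas the substituent exchange on the aniline ring gave an at least 4.0-fold lower number from compound 1 to compound 2 (0.60 log units; beyond the scatter); a change at one aromatic position of this core can thus exceed the scatter while a change at another stays within it, at least for these two pairs. Nothing among the measurements shown accounts for this result.

Going by these compounds, it remains open whether this position would stay as unresponsive with other groups, such as an amine, a carboxylic acid or a longer alkyl chain, since only isopropyl and chloro are compared here. On these data alone, it is also open whether chloro and isopropyl would remain indistinguishable with the methoxy of compound 1 on the aniline ring, as the reading for compound 1 in this assay is only a limit.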